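The source may report more compounds than this note shows. Statements on the series, on what has been measured and on what is new or still open speak of the compounds shown alone.

Compound 1, `Nc1ccccc1NC(=O)c1ccc(CNCc2nc(-c3ccc(Cl)cc3)no2)cc1`: in an assay on isolated protein for inhibition of histone deacetylase 8 (Homo sapiens), read by fluorescence, with a stated time of 20 min (on this read-out higher numbers stand for weaker inhibition and lower numbers for stronger inhibition), compound 1 gives > 10000 nM, which is a limit of the assay and not a number.
Compound 2, `Nc1ccccc1NC(=O)c1ccc(CNCc2nc(-c3ccc(F)cc3)no2)cc1`: in this assay compound 2 gives > 10000 nM, again a limit.
Compound 3, `Nc1ccccc1NC(=O)c1ccc(CNCc2nc(-c3cccs3)no2)cc1`: in this assay compound 3 gives > 10000 nM, once more a limit.

Compound 1 therefore stands only at the limit of this assay, and so do its two companions: the limit of > 10000 nM in this assay, at which 3 of the 3 values shown sit. The measured steps between them carry no readable size: a step that the two limits leave unreadable from compound 1 to compound 2, a step that the two limits leave unreadable from compound 1 to compound 3 and a step that the two limits leave unreadable from compound 2 to compound 3 all run from one limit to another. Each of them changes only the aromatic group at the far end of the shared core, never the part that binds the amide.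

Compound 4, `O=C(NO)c1ccc(CNCc2nc(-c3ccc(Cl)cc3)no2)cc1`, changes exactly that other end. Against compound 1 the difference is hydroxy in place of 2-aminophenyl on an amide-type nitrogen. Among the compounds with values here, no measured step touches this position, and the three that exist are unreadable, so they set no size for what follows; the expectation rests on the structural change alone. For compound 4 the step of an at least 66-fold lower number from compound 1 to compound 4 (1.82 log units; beyond the scatter) is expected to run toward stronger inhibition, far beyond the scatter, and to bring the value off the limit. Compound 4 is estimated at 150 nM, with a range from 20 nM to 1500 nM.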

Compound 4, half-maximal inhibitory concentration: 350 nM
Estimate against measurement, compound 4: 2.3-fold (0.37 log units) below; low and high end bracket the measured number.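

In this assay, within the data shown here, hydroxy in place of 2-aminophenyl on the amide-type nitrogen gives an at least 28-fold lower number from compound 1 to compound 4 (1.45 log units; beyond the scatter), the first reading here that is a number and not a limit. Among these compounds, this shows that the end of the molecule left untouched by the earlier steps can move the read-out a long way, even with the 4-chlorophenyl group and the rest of the shared core unchanged. The earlier steps among compound 1, compound 2 and compound 3 cannot be read, and all three compounds stand at the same limit: the limit of > 10000 nM in this assay, at which 3 of the 4 values shown sit.

Only one replacement on this nitrogen is shown, so it remains open what a methoxy group or a plain amine there would give, and how closely the result depends on hydroxy itself. From the compounds shown here alone, it also remains open whether 4-fluorophenyl or thiophen-2-yl, which cannot be told apart from 4-chlorophenyl while the values sit at a limit, would shift the read-out in a compound that also carries hydroxy.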